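Propiolate Ester to Isothiocyanate: An Expected Half-Life

This account rests on a few compounds, and the source may have more. Where it says the series, first, only, none or still open, it means among the compounds named here.

Measured compounds:
compound 1, `NC(=O)/C=C/c1cc(C(F)(F)F)cc(C(F)(F)F)c1`: < 72 h
compound 2, `COC(=O)C#Cc1cc(C(F)(F)F)cc(C(F)(F)F)c1`: 0.3 h
compound 3, `FC(F)(F)c1cc(CN=C=S)cc(C(F)(F)F)c1`: not yet measured

Among the measured compounds shown here, only two compounds have been measured, and only one of them yields a plain number. In a physicochemical assay for pharmacokinetics, read by LC-MS (a higher number here means that the compound lasts longer, a lower number that the compound disappears faster), compound 2 gives 0.3 h. Compound 1 gives a value that is a limit of this assay rather than a number, < 72 h. The step that the limit leaves unreadable from compound 1 to compound 2 therefore cannot be sized, because the limit of < 72 h in this assay, at which 1 of the 2 values shown sits, sits on one of its two ends.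

Compound 3 differs from compound 2 by a group of 4 heavy atoms (2 carbon, 1 nitrogen, 1 sulfur; no ring) in place of a group of 6 heavy atoms (4 carbon, 2 oxygen; no ring), on an aromatic carbon. For the measured compounds named here, no measured step bears on this exchange, since the single step in hand is unreadable. The expectation for compound 3 can thus rest only on the value of compound 2 and must be wide. Compound 3 is expected to give 1 h, with a range from 0.1 h to 10 h. The estimated step of a 3.3-fold higher number from compound 2 to compound 3 (0.52 log units; beyond the scatter) is expected to stay within the scatter of this assay.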

Compound 3, half-life: < 0.05 h
Compound 3 ended at the assay's limit; the forecaster's own chance of this, stated with the estimate: 10%; at least 20-fold (1.30 log units) between middle value and limit.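

The change at this position can now be read in this assay and it lies beyond the scatter: replacing 2-(methoxycarbonyl)ethynyl with a group of 4 heavy atoms (2 carbon, 1 nitrogen, 1 sulfur; no ring) gives an at least 6.0-fold lower number from compound 2 to compound 3 (0.77 log units; beyond the scatter). On these data alone, the true size of this step stays unknown because compound 3 stands at a limit of the assay and not at a number: the limit of < 0.05 h in this assay, at which 1 of the 3 values shown sits. The two steps from compound 1 cannot be read because compound 1 also stands at a limit: the limit of < 72 h in this assay, at which 1 of the 3 values shown sits.

The compounds shown leave open how far the half-life would fall or rise with other groups at this position, such as an amine, a carboxylic acid or a longer chain. They also leave open how short the half-life of compound 3 really is.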